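The source may report more compounds than this note shows. Statements on the series, on what has been measured and on what is new or still open speak of the compounds shown alone.

Compound 1 `O=C1N=C(N2N=C(c3ccccc3)CC2c2ccccc2O)S/C1=C1/C(=O)Nc2ccccc21` gives 4730 nM in a functional assay on cells (Cancer cell lines, Homo sapiens) for cytotoxicity, read by sulforhodamine B assay, with a stated time of 48 h; a higher number here means a weaker inhibitor of growth, a lower number a stronger inhibitor of growth. Compound 2 `COc1ccc(C2=NN(C3=NC(=O)/C(=C4\C(=O)Nc5ccccc54)S3)C(c3ccc(OC)cc3)C2)cc1` gives 91600 nM. Compound 3 `O=C1N=C(N2N=C(c3ccccc3)CC2c2ccc(Cl)cc2)S/C1=C1/C(=O)Nc2ccccc21` gives 6290 nM.

Compound 3 stands second highest of these three numbers; it and compound 1 lie within the scatter of each other, while compound 2 sits well beyond it. Compound 4 `COc1ccc(C2=NN(C3=NC(=O)/C(=C4\C(=O)Nc5ccccc54)S3)C(c3ccc(Cl)cc3)C2)cc1` differs from compound 3 by methoxy in place of hydrogen on an aromatic carbon. Among the measured compounds shown here, no measured step carries this change; the only measured step, a 1.3-fold higher number from compound 1 to compound 3 (0.12 log units; within the scatter), alters the phenyl on the saturated ring carbon and lies within the scatter. Compound 2, which also bears a methoxy group on each phenyl, gives the highest number. A step upward in this assay is therefore expected, of the size a 3.2-fold higher number from compound 3 to compound 4 (0.50 log units; beyond the scatter). Compound 4 is expected at 20000 nM, within 6000 nM to 70000 nM.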

Compound 4, concentration for total growth inhibition: 100000 nM
The estimate for compound 4 lay 5.0-fold (0.70 log units) below the measured number; measured number above the stated range.
By their numbers in this assay, from the lowest: compounds 1 and 3 (each within the scatter of the next); then compounds 2 and 4 (each within the scatter of the next).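

Placing a methoxy on this phenyl, para to a large group, weakens growth inhibition sharply in this assay (a 16-fold higher number from compound 3 to compound 4 (1.20 log units; beyond the scatter)). With that methoxy in place, the group on the other phenyl makes no clear difference (a 1.1-fold higher number from compound 2 to compound 4 (0.04 log units; within the scatter)), although the earlier step between 2-hydroxyphenyl and 4-chlorophenyl was also within the scatter. The evidence offers no explanation for the methoxy step.

On these data alone, it remains open what an amine or a carboxylic acid at this position would do. As far as these compounds go, it is also open whether the methoxy step holds alongside the 2-hydroxyphenyl of compound 1.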